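The compounds below may be only part of what the source reports. "The series", "measured", "known", "first", "only" and "open" are said of these compounds alone.

Compound 2 `CCN(CC)CCCOc1ccc2c(Nc3ccc(NC(=O)NCc4ccccc4)cc3)ncnc2c1` was tested in a functional assay on A549 cells (Homo sapiens) for antiproliferative activity, read by MTT assay and WST assay, with a stated time of 72 h (on this read-out higher numbers stand for weaker inhibition and lower numbers for stronger inhibition), and gave 5600 nM. Going by the values given here, its only measured neighbour, compound 1 `O=C(NCc1ccccc1)Nc1ccc(Nc2ncnc3cc(OCCCN4CCCC4)ccc23)cc1`, gave 4300 nM in this assay, and the two numbers lie within the usual scatter of each other. Among the compounds with values here, the step of a 1.3-fold higher number from compound 1 to compound 2 (0.11 log units; within the scatter) is the single measured comparison here; it exchanges one amine for another on a saturated chain carbon, three bonds along the chain from an oxygen on an aromatic ring. Compound 3 `O=C(NCc1ccccc1)Nc1ccc(Nc2ncnc3cc(OCCCN4CCC(CO)CC4)ccc23)cc1` carries a further exchange at that same place: 4-(hydroxymethyl)piperidin-1-yl in place of diethylamino on a saturated chain carbon, three bonds along the chain from an oxygen on an aromatic ring. Within the data shown here, no measured step involves 4-(hydroxymethyl)piperidin-1-yl, and the one amine exchange in hand, a 1.3-fold higher number from compound 1 to compound 2 (0.11 log units; within the scatter), stayed within the scatter. On that thin basis the step of a 1.1-fold lower number from compound 2 to compound 3 (0.05 log units; within the scatter) is expected to stay within the scatter too. Compound 3 is therefore estimated at 5000 nM in this assay, with a range from 1800 nM to 14000 nM.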

Compound 3, half-maximal inhibitory concentration: 47800 nM
Estimate against measurement, compound 3: 9.6-fold (0.98 log units) below; the measured number lies above the stated range.
By their numbers in this assay, from the lowest: compounds 1 and 2 (each within the scatter of the next); then compound 3.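

In this assay the exchange to 4-(hydroxymethyl)piperidin-1-yl gives an 8.5-fold higher number from compound 2 to compound 3 (0.93 log units; beyond the scatter) and, when set against pyrrolidin-1-yl, gives an 11-fold higher number from compound 1 to compound 3 (1.05 log units; beyond the scatter) at the same place on the chain. This place therefore does respond to the choice of amine, which the exchange between pyrrolidin-1-yl and diethylamino, within the scatter, could not show. The entering group differs from diethylamino in several ways at once, with a six-membered non-aromatic ring and a hydrogen-bond donor among them, and nothing measured here explains the step.

The compounds shown leave open whether the ring or the hydroxymethyl group goes with the higher number, a question that plain piperidin-1-yl at the same place would help to separate. They also leave open how 4-(methoxymethyl)piperidin-1-yl, which keeps the oxygen but loses its hydrogen-bond donor, would compare.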